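The compounds below may be only part of what the source reports. "The series", "measured", "known", "first", "only" and "open" are said of these compounds alone.

Measured compounds in a functional assay on B16 cells (Mus musculus) for cytotoxicity, read by MTT assay, with a stated time of 72 h; a lower number here means a stronger inhibitor, a higher number a weaker inhibitor:
Compound 1 `C#CCOc1cccc(/C=C/C(=O)Nc2cc(C(=O)c3cc(OC)c(OC)c(OC)c3)ccc2OC)c1`: 12200 nM
Compound 2 `COc1ccc(C(=O)c2cc(OC)c(OC)c(OC)c2)cc1NC(=O)/C=C/c1ccc(C(F)(F)F)cc1`: 100 nM
Compound 3 `COc1cc(/C=C/C(=O)Nc2cc(C(=O)c3cc(OC)c(OC)c(OC)c3)ccc2OC)ccc1F`: 16300 nM

Compound 1 stands second highest of the three numbers in this assay; compound 3 lies nearest, a 1.3-fold higher number from compound 1 to compound 3 (0.13 log units; within the scatter), and compound 2 furthest, a 120-fold lower number from compound 1 to compound 2 (2.09 log units; beyond the scatter). Going by the values given here, the one large step recorded between them, a 160-fold higher number from compound 2 to compound 3 (2.21 log units; beyond the scatter), like the step to compound 2, alters only the aryl group on the double-bonded chain.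

Compound 4 `C#CCOc1cccc(/C=C/C(=O)Nc2cc(C(=O)c3cc(OC)c(OC)c(OC)c3)cc(OC)c2OC)c1` differs from compound 1 elsewhere: methoxy in place of hydrogen on an aromatic carbon. Among the compounds with values here, no measured step touches this part of the shared core, so none of the recorded steps bears on the change. With nothing to go on, the expected step from compound 1 to compound 4 in this assay is none beyond the scatter, a 1.0-fold lower number from compound 1 to compound 4 (0.01 log units; within the scatter). Compound 4 is therefore estimated at 12000 nM, with a range from 4000 nM to 40000 nM.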

Compound 4, half-maximal inhibitory concentration: 5100 nM
Compound 4: middle estimate off by 2.4-fold (0.37 log units), on the high side; measured number inside the range.
By their numbers in this assay, from the lowest: compound 2; then compound 4; then compounds 1 and 3 (each within the scatter of the next).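

In this assay, methoxy in place of hydrogen on this aromatic carbon, ortho to a methoxy group, gives a 2.4-fold lower number from compound 1 to compound 4 (0.38 log units; beyond the scatter) as a modest step. Going by these compounds alone, this is the first recorded sign that this part of the shared core affects the read-out, since the earlier steps altered only the aryl group on the double-bonded chain. Nothing at hand accounts for the step.

On these data alone, whether the same change would shift the number on the 4-(trifluoromethyl)phenyl background of compound 2 remains open. So does the outcome with an ethoxy group or an amine on this carbon.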